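Methoxy for fluoro on the anilino ring of compound 2

A few compounds are considered here, and "the series" means these few. Any claim that something is new, unique, unknown or untested is made for them only; others in the source may bear on it.

Compound 2 `O=C1C=C(Nc2cccc(F)c2)C(=O)c2c1nc1n2[C@H]2OC[C@@H](O)[C@H]2OC1` gives 6440 nM in a functional assay on HeLa cells (Homo sapiens) for inhibition, read by sulforhodamine B assay (a higher number here means a weaker inhibitor, a lower number a stronger inhibitor), the highest of the two numbers here; its nearest neighbour is compound 1 `O=C1C(Nc2ccc(Br)cc2)=CC(=O)c2c1nc1n2[C@H]2OC[C@@H](O)[C@H]2OC1` with 5220 nM, a gap within the scatter. Compound 3 `COc1cccc(NC2=CC(=O)c3c(nc4n3[C@H]3OC[C@@H](O)[C@H]3OC4)C2=O)c1` returns only the limit > 8000 nM, which is a limit and not a number (the limit of > 8000 nM in this assay, at which 1 of the 3 values shown sits). The step from compound 2 to compound 4 `COc1cccc(NC2=CC(=O)c3nc4n(c3C2=O)[C@H]2OC[C@@H](O)[C@H]2OC4)c1` is methoxy in place of fluoro on an aromatic carbon. For the measured compounds named here, the one measured step that bears on it is an at least 1.5-fold higher number from compound 1 to compound 3 (0.18 log units; that floor lies within the scatter), a 3-methoxyphenyl entering on the amine nitrogen of the core of compound 1. A similar, modestly higher number is therefore expected, a 1.5-fold higher number from compound 2 to compound 4 (0.17 log units; within the scatter), with a fair chance of a limit. Compound 4 is estimated at 9500 nM, between 4500 nM and 20000 nM.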

Compound 4, half-maximal inhibitory concentration: 4280 nM
The estimate for compound 4 lay 2.2-fold (0.35 log units) above the measured number, outside the stated range (below it).
By their numbers in this assay, from the lowest: compounds 4, 1 and 2 (each within the scatter of the next). At a limit, above all of these: compound 3.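

In this assay, methoxy in place of fluoro on this aromatic carbon gives a 1.5-fold lower number from compound 2 to compound 4 (0.18 log units; within the scatter), so this change leaves the number within the scatter. Compound 4 returns a number, which shows that the 3-methoxyphenyl group does not by itself bring a limit. Compound 3, which carries the same group, remains a limit and not a number: the limit of > 8000 nM in this assay, at which 1 of the 4 values shown sits.

From the compounds shown here alone, whether an amine, a carboxylic acid or a nitrile on this aromatic carbon would move the number beyond the scatter stays open. Going by these compounds, the true gap between compound 3 and compound 4 also stays open.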